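The compounds below may be only part of what the source reports. "The series", "measured", "known", "first", "only" and "open" are said of these compounds alone.

In a functional assay on PC-3 cells (Homo sapiens) for inhibition, read by sulforhodamine B assay, with a stated time of 48 h (a higher number here means a weaker inhibitor of growth, a lower number a stronger inhibitor of growth), the measured compounds stand as follows:

Compound 1, `CC1=CC[C@H](C(C)(C)NC(=S)N/N=C/c2ccccc2)CC1`, gives 1300 nM.
Compound 2, `CC1=CC[C@H](C(C)(C)NC(=S)N/N=C/c2ccc(N(C)C)cc2)CC1`, reaches only the limit < 40 nM.
Compound 3, `CC1=CC[C@H](C(C)(C)NC(=S)N/N=C/c2ccc(F)cc2)CC1`, reaches only the limit < 40 nM.

Compound 3 therefore stands at a limit of this assay, not at a number, and it shares that position with one other value; the limit of < 40 nM in this assay, at which 2 of the 3 values shown sit, marks this limit. Compound 4, `CC1=CC[C@H](C(C)(C)NC(=S)N/N=C/c2cccs2)CC1`, differs from compound 3 by thiophen-2-yl in place of 4-fluorophenyl on a carbon with a double bond to nitrogen. Within the data shown here, no measured step bears directly on this exchange. The steps that exist concern substitution on the aromatic ring: an at least 32-fold lower number from compound 1 to compound 2 (1.51 log units; beyond the scatter) and an at least 32-fold lower number from compound 1 to compound 3 (1.51 log units; beyond the scatter), both large, while a step that the two limits leave unreadable from compound 2 to compound 3. Compound 1 with a bare phenyl is the weakest measured compound, and compound 4 carries neither of the substituents that produced the large steps. Compound 4 is therefore expected to sit between compound 1 and the limit, with the expected step of an at least 7.5-fold higher number from compound 3 to compound 4 (0.87 log units; beyond the scatter). The estimate for compound 4 in this assay is 300 nM, within 40 nM to 2000 nM.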

Compound 4, concentration for 50% growth inhibition: 17800 nM
Compound 4: the middle estimate sits 59-fold (1.77 log units) below what was measured, and the stated range ends below it.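

In this assay, the step of an at least 440-fold higher number from compound 3 to compound 4 (2.64 log units; beyond the scatter) shows that thiophen-2-yl in place of 4-fluorophenyl costs a great deal of growth inhibition, and its true size stays unknown, as compound 3 stands at a limit: the limit of < 40 nM in this assay, at which 2 of the 4 values shown sit.

The earlier steps shown here at this place all went toward lower numbers, whereas thiophen-2-yl in place of phenyl goes the other way, with a 14-fold higher number from compound 1 to compound 4 (1.14 log units; beyond the scatter). The lack of a ring substituent alone does not account for this, as compound 1, with its phenyl, carries none either.

Still open, going by these compounds, is whether dimethylamino or fluoro on the thiophen-2-yl ring would bring the same large steps seen on phenyl. Also open, on these data alone, is how a furan or pyridine ring would stand at this place.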